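The compounds below may be only part of what the source reports. "The series", "measured", "known", "first", "only" and "open" are said of these compounds alone.

Compound 1 `Cc1cc(-c2ccccc2)n(/C(N)=N/S(=O)(=O)c2cc(C)c(Cl)cc2SCc2cccc3ccccc23)n1` and compound 2 `Cc1cc(-c2ccccc2)n(/C(N)=N/S(=O)(=O)c2cc(C)c(Cl)cc2SCc2cccc(C(F)(F)F)c2)n1` share a common core and differ only in the group on the sulfur-bound chain carbon. Among the compounds with values here, in an ADME assay on microsomes from liver (Homo sapiens) for metabolic stability, read by LC-MS, using NADPH, tested at 5 uM (on this read-out higher numbers stand for a longer-lived compound and lower numbers for a shorter-lived compound), compound 1 gives 0.256 h, the higher of the two numbers measured so far, and compound 2 gives 0.169 h. Within the data shown here, the single measured step, a 1.5-fold lower number from compound 1 to compound 2 (0.18 log units; within the scatter), lies within the scatter. Compound 3 `Cc1cc(S(=O)(=O)/N=C(\N)n2nccc2-c2ccccc2)c(SCc2cccc3ccccc23)cc1Cl` is a different change to compound 1: hydrogen in place of methyl on an aromatic carbon, next to the ring nitrogen. Among the measured compounds shown here, no measured step touches this part of the molecule, so the only guidance is that the one change tried so far, at another position, left the half-life essentially unchanged. For compound 3 the expected step is a 1.2-fold lower number from compound 1 to compound 3 (0.07 log units; within the scatter), within the scatter. The estimate for compound 3 is 0.22 h, with a range from 0.1 h to 0.45 h.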

Compound 3, half-life: 0.268 h
Beside the measured number, compound 3's estimate is 1.2-fold (0.09 log units) below it; the range from low to high includes it.
By their numbers in this assay, from the lowest: compounds 2, 1 and 3 (each within the scatter of the next).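

In this assay, within the data shown here, the change from 3-methyl-5-phenyl-1H-pyrazol-1-yl to 5-phenyl-1H-pyrazol-1-yl gives a 1.0-fold higher number from compound 1 to compound 3 (0.02 log units; within the scatter) and is the first reading at this position. With methyl or with hydrogen on this aromatic carbon, the half-life of the pair does not separate, so the methyl is not needed for the number that compound 1 gives. Nothing available accounts for this result.

Only hydrogen and methyl are shown at this position, so it remains open whether a larger or different group there, such as an ethyl, a methoxy or a carboxylic acid, would shift the half-life. From the compounds shown here alone, it is also open whether the same exchange would read alike with the 3-(trifluoromethyl)phenyl group of compound 2 in place of naphthalen-1-yl.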